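Replacing a Dichlorophenyl Group with a Hydroxy-Methoxyphenyl Group

This account rests on a few compounds, and the source may have more. Where it says the series, first, only, none or still open, it means among the compounds named here.

Measured in a functional assay on HT-1080 cells (Homo sapiens) for cytotoxicity, read by MTT assay, with a stated time of 72 h; a lower number here means a stronger inhibitor, a higher number a weaker inhibitor:
- compound 1 `COc1ccc(/C=C2\CCC/C(=C\c3cccc(Br)c3)C2=O)cc1OC`: 5200 nM
- compound 2 `COc1ccc(/C=C2\CCC/C(=C\c3ccc(Cl)cc3Cl)C2=O)cc1OC`: 10500 nM
- compound 3 `COc1ccc(/C=C2\CCC/C(=C\c3cc(Cl)cc(Cl)c3)C2=O)cc1OC`: 3000 nM

Compound 3 gives 3000 nM. The data show a 1.7-fold lower number from compound 1 to compound 3 (0.24 log units; within the scatter), so no order can be drawn on that step, while a 3.5-fold lower number from compound 2 to compound 3 (0.54 log units; beyond the scatter) sets it clearly on the stronger side of that pair.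

The account now turns to compound 4 `COc1cc(/C=C2\CCC/C(=C\c3ccc(OC)c(OC)c3)C2=O)ccc1O`, which carries 4-hydroxy-3-methoxyphenyl in place of 3,5-dichlorophenyl on a double-bonded chain carbon bound to a double-bonded ring carbon.

The measured steps all act at this same place, but each only exchanges one chlorinated or brominated phenyl for another. Besides the two above, there is a 2.0-fold higher number from compound 1 to compound 2 (0.31 log units; beyond the scatter). None of them shows what a hydroxy-bearing phenyl does here, so they give only a rough scale. Since an exchange at this place already took compound 2 to 10500 nM, a modest step towards a higher number in this assay is expected, not a large one.

The expected change is a 2.2-fold higher number from compound 3 to compound 4 (0.34 log units; beyond the scatter).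

For compound 4 the estimated value is 6500 nM, with an expected range of 2000 nM to 20000 nM.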

Compound 4, half-maximal inhibitory concentration: 4600 nM
For compound 4 the middle estimate is 1.4-fold (0.15 log units) above the measured one; the measured number falls inside the stated range.
By their numbers in this assay, from the lowest: compounds 3, 4 and 1 (each within the scatter of the next); then compound 2.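

In this assay the place on a double-bonded chain carbon bound to a double-bonded ring carbon also accepts 4-hydroxy-3-methoxyphenyl, the only group shown here that carries a hydrogen-bond donor and no halogen: a 1.5-fold higher number from compound 3 to compound 4 (0.19 log units; within the scatter) and a 1.1-fold lower number from compound 1 to compound 4 (0.05 log units; within the scatter) both leave compound 4 inseparable from the halogen-bearing compound it is compared with. Only the 2,4-dichlorophenyl group stands apart from the new group, with a 2.3-fold lower number from compound 2 to compound 4 (0.36 log units; beyond the scatter) as the one step that can be read as a real change, so among these four compounds a halogen on this phenyl is not required to reach the level of compound 3 and compound 1. Nothing available explains why such different groups give numbers this close.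

The hydroxy and the methoxy enter together in a single step, which leaves open what either one does alone at this place. Going by these compounds, how this place would answer to a phenyl bearing an amine or a carboxylic acid, or to a longer chain in place of the phenyl, also remains open.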